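Isobutyl to Sec-Butyl on the Amine-Bearing Chain

The source may report more compounds than this note shows. Statements on the series, on what has been measured and on what is new or still open speak of the compounds shown alone.

Compound 1 `COc1ccc(-c2ccc(N(C[C@@H](N)CC(C)C)C(=O)[C@@H]3C[C@H]3c3ccccc3)cc2)cc1` holds the lower of the two numbers in a functional assay for agonist activity at G protein-coupled receptor 88 (Homo sapiens), read by HTRF and cAMP accumulation (a higher number here means that more compound is needed for the effect, a lower number that less compound is needed), where compound 1 gives 330 nM. Compound 2 `COc1ccccc1-c1ccc(N(C[C@@H](N)CC(C)C)C(=O)[C@@H]2C[C@H]2c2ccccc2)cc1` gives 3200 nM; swapping 4-methoxyphenyl for 2-methoxyphenyl shows a 9.7-fold higher number from compound 1 to compound 2 (0.99 log units; beyond the scatter). Compound 3 `CC[C@H](C)[C@H](N)CN(C(=O)[C@@H]1C[C@H]1c1ccccc1)c1ccc(-c2ccc(OC)cc2)cc1` differs from compound 1 by sec-butyl in place of isobutyl on a saturated chain carbon bound to an amine nitrogen and a saturated chain carbon. Among the compounds with values here, no measured step touches this side chain: the single step so far concerns the aromatic part and says nothing about the amine-bearing carbon. For compound 3 the expected step is therefore a 1.2-fold higher number from compound 1 to compound 3 (0.08 log units; within the scatter), within the scatter. Compound 3 is estimated at 400 nM, in a range from 130 nM to 1500 nM.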

Compound 3, half-maximal effective concentration: 120 nM
Compound 3: the middle estimate sits 3.3-fold (0.52 log units) above what was measured; the measured number lies below the stated range.
By their numbers in this assay, from the lowest: compound 3; then compound 1; then compound 2.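

Within the data shown here, this is the first change on the amine-bearing side chain, and it shows that this position responds to the arrangement of its carbons alone. In this assay sec-butyl in place of isobutyl gives a 2.8-fold lower number from compound 1 to compound 3 (0.44 log units; beyond the scatter) with the heavy-atom count unchanged. Nothing shown here gives a reason for this shift.

From the compounds shown here alone, whether a longer chain such as n-pentyl or a ring such as cyclohexyl would lower the number further remains open. So does the effect of reversing the defined stereocentre of the sec-butyl group.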